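Aryl swap at the saturated carbon: compound 3 to compound 4

A few compounds are considered here, and "the series" means these few. Any claim that something is new, unique, unknown or untested is made for them only; others in the source may bear on it.

Compound 1 `Oc1c(C(Nc2ccccn2)c2ccccc2Cl)ccc2cccnc12` gives 500 nM in an assay for inhibition of protein disulfide-isomerase (Homo sapiens), with a stated time of 1 h; on this read-out higher numbers stand for weaker inhibition and lower numbers for stronger inhibition. Compound 2 `Oc1cccc(C(Nc2ccccn2)c2ccc3cccnc3c2O)c1Cl` gives 370 nM in this assay, and compound 3 `Oc1c(C(Nc2ccccn2)c2ccccc2F)ccc2cccnc12` gives 470 nM in this assay. Compound 3 thus stands second highest of the three numbers, nearest to compound 1 and furthest from compound 2, both gaps within the scatter: a 1.1-fold lower number from compound 1 to compound 3 (0.03 log units; within the scatter) and a 1.3-fold higher number from compound 2 to compound 3 (0.10 log units; within the scatter).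

Compound 4 `Cc1ccc(C)c(C(Nc2ccccn2)c2ccc3cccnc3c2O)c1` differs from compound 3 by 2,5-dimethylphenyl in place of 2-fluorophenyl on a saturated chain carbon bound to an aromatic carbon and a nitrogen on an aromatic ring. Going by the values given here, two measured steps bear on this. The step of a 1.3-fold higher number from compound 2 to compound 3 (0.10 log units; within the scatter) already exchanges one aryl group for another at that same carbon and stays within the scatter, and the step of a 1.1-fold lower number from compound 1 to compound 3 (0.03 log units; within the scatter) puts fluoro in place of chloro on an aromatic carbon and is likewise within the scatter. The step of a 1.4-fold lower number from compound 1 to compound 2 (0.13 log units; within the scatter), hydroxy in place of hydrogen on an aromatic carbon, is also flat. Nothing seen so far points to a move beyond the scatter in this assay in either direction. Compound 4 is therefore expected to give about 500 nM in this assay, between 250 nM and 1000 nM. The expected step is a 1.1-fold higher number from compound 3 to compound 4 (0.03 log units; within the scatter).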

Compound 4, half-maximal inhibitory concentration: 730 nM
Beside the measured number, compound 4's estimate is 1.5-fold (0.16 log units) below it; measured number inside the range.
By their numbers in this assay, from the lowest: compounds 2, 3, 1 and 4 (each within the scatter of the next).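

Going by these compounds alone, at the saturated chain carbon bound to an aromatic carbon and a nitrogen on an aromatic ring, 2,5-dimethylphenyl is the first aryl group here with only carbon substituents. Its exchange for 2-fluorophenyl (a 1.6-fold higher number from compound 3 to compound 4 (0.19 log units; within the scatter)), 2-chlorophenyl (a 1.5-fold higher number from compound 1 to compound 4 (0.16 log units; within the scatter)) and 2-chloro-3-hydroxyphenyl (a 2.0-fold higher number from compound 2 to compound 4 (0.30 log units; within the scatter)) stays within the scatter in this assay, so neither halogen nor hydroxy on this aryl group is required for a number in this range among the four compounds. No measurement at hand accounts for this flat response.

Still open, from the compounds shown here alone, is whether an amine or a carboxylic acid on this aryl group would move the number beyond the scatter. Also open, going by these compounds, is the effect of replacing the aryl group with cyclohexyl or a longer alkyl chain.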